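Hydroxy for amino on the aryl ring: compound 2 to compound 3

The compounds below may be only part of what the source reports. "The series", "measured", "known", "first", "only" and "open" are said of these compounds alone.

Measured so far:
- compound 1, `COC(=O)C1=C(C)N=C(C)/C(=C(/O)OC)C1c1c(F)cccc1Cl`: 7.59 nM
- compound 2, `COC(=O)C1=C(C)N=C(C)/C(=C(\O)OC)C1c1cccc(N)c1`: 2000 nM

In a functional assay (muscle tissue) with Cavia porcellus as the target (a lower number here means that less compound is needed, a higher number that more compound is needed for the effect), compound 1 gives 7.59 nM. Compound 2 gives 2000 nM in this assay, which is the highest of the two numbers; the nearest neighbour is compound 1, whose number is far lower, well beyond the scatter. Within the data shown here, no pair of measured compounds differs in only one place, so no single-point step is available from the numbers themselves.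

Compound 3, `COC(=O)C1=C(C)N=C(C)/C(=C(\O)OC)C1c1cccc(O)c1`, has not been measured in this assay. It differs from compound 2 in one place: hydroxy in place of amino on an aromatic carbon. The change sits on an aromatic carbon of a six-membered aromatic ring of carbon only, meta to a large group, and exchanges one donor-acceptor group for another of the same size and charge.

Among the measured compounds shown here, with no measured step of this kind to lean on, the expected step from compound 2 to compound 3 is a 1.3-fold lower number from compound 2 to compound 3 (0.12 log units; within the scatter), that is a small move downward, close to the scatter. Compound 3 is therefore estimated at 1500 nM in this assay, with a range from 400 nM to 6000 nM.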

Compound 3, half-maximal effective concentration: 1000 nM
Compound 3: middle estimate off by 1.5-fold (0.18 log units), on the high side; low and high end bracket the measured number.
By their numbers in this assay, from the lowest: compound 1; then compounds 3 and 2 (each within the scatter of the next).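

Among these compounds, the exchange of amino for hydroxy gives the only single-place comparison so far: in this assay it reads a 2.0-fold lower number from compound 2 to compound 3 (0.30 log units; within the scatter), so on this aromatic carbon, meta to a large group, the two groups cannot be told apart. Compound 2 and compound 3 carry the same count of hydrogen-bond donors and acceptors and no net charge, and this one exchange leaves the read-out within the scatter. No measurement of any property of either group bears on this result, so the step stands as an observation without an explanation.

Among the compounds shown here, no single-place step links compound 2 or compound 3 to compound 1 , whose number of 7.59 nM therefore cannot be assigned to any one structural feature. Also open, going by these compounds, is what a group of another kind on the same aromatic carbon, such as a carboxylic acid, a methoxy group or a dimethylamino group, would do to the number in this assay; the present pair speaks only for amino and hydroxy.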